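Working notes: from compound 2 to compound 3

The compounds below may be only part of what the source reports. "The series", "measured", "known", "first", "only" and "open" are said of these compounds alone.

Measured so far in a functional assay on A549 cells (Homo sapiens) for cytotoxicity, read by MTT assay, with a stated time of 72 h; on this read-out higher numbers stand for weaker inhibition and lower numbers for stronger inhibition:
- compound 1 `CCCN1C/C(=C\c2ccc(OC)c(OC)c2)C(=O)/C(=C/c2ccc(OC)c(OC)c2)C1` gives 4200 nM 
- compound 2 `COc1ccc(/C=C2\CN(C)C/C(=C\c3ccc(OC)c(OC)c3)C2=O)cc1OC` gives 1300 nM 

For the measured compounds named here, compound 2 holds the lower of the two numbers in this assay, so it is the stronger of this pair, and compound 1 is its only neighbour. Next comes compound 3 `CCN1C/C(=C\c2ccc(OC)c(OC)c2)C(=O)/C(=C/c2ccc(OC)c(OC)c2)C1`. The change from compound 2 is methyl in place of hydrogen on a saturated chain carbon bound to an amine nitrogen in a ring, with methyl in place of hydrogen on a saturated chain carbon bound to an amine nitrogen in a ring.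

Going by the values given here, one measured step bears on this: a 3.2-fold lower number from compound 1 to compound 2 (0.51 log units; beyond the scatter), where hydrogen replaces ethyl at that same place. At this carbon, compound 3 carries methyl, compound 2 hydrogen and compound 1 ethyl, so compound 3 is an intermediate case. A single step gives a direction but does not show how evenly the change divides. A move toward a higher number is expected, smaller than the measured step and probably not clear of the scatter. The estimated move is a 1.8-fold higher number from compound 2 to compound 3 (0.25 log units; within the scatter) in this assay. For compound 3 the expected value is 2300 nM, with 1200 nM to 4500 nM as the estimated range.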

Compound 3, half-maximal inhibitory concentration: 3600 nM
The estimate for compound 3 lay 1.6-fold (0.19 log units) below the measured number, and the stated range covers the measured number.
By their numbers in this assay, from the lowest: compound 2; then compounds 3 and 1 (each within the scatter of the next).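

In this assay, methyl in place of hydrogen on a saturated chain carbon bound to an amine nitrogen in a ring accounts for most of the change seen earlier at this position, with a 2.8-fold higher number from compound 2 to compound 3 (0.44 log units; beyond the scatter), a step beyond the scatter. The next change along the same chain cannot be told apart from repeat variation, with a 1.2-fold lower number from compound 1 to compound 3 (0.07 log units; within the scatter), a step within the scatter, so the earlier change does not divide evenly and only the first of these two steps can be read as real. Nothing available on these compounds explains this uneven split.

The compounds shown carry only short unbranched alkyl chains at this nitrogen, so it remains open whether a branched chain such as isopropyl, a benzyl group or a chain ending in a hydroxyl group would keep the number near that of compound 2 or near that of compound 3. From the compounds shown here alone, it is also open whether the same uneven split would hold with other groups on the core of compound 2, or on cells other than those in this assay.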